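The compounds below may be only part of what the source reports. "The series", "measured", "known", "first", "only" and "open" are said of these compounds alone.

Compound 1 `CCc1nc2sccn2c1/C=N/OCc1ccc(Cl)c(Cl)c1` gives 2600 nM in an assay on HepG2 cells for agonist activity at nuclear receptor subfamily 1 group I member 3 (Homo sapiens), read by a luciferase reporter, with a stated time of 23 h; on this read-out lower numbers stand for an effect already at smaller amounts and higher numbers for an effect only at larger amounts of compound.
Compound 2 `FC(F)(F)c1ccc(CO/N=C/c2c(-c3ccc4ccccc4c3)nc3occn23)cc1` gives 470 nM in this assay.
Compound 3 `Clc1ccc(CO/N=C/c2c(-c3ccc4ccccc4c3)nc3sccn23)cc1Cl` gives 380 nM in this assay.

Compound 1 stands highest of the three numbers; compound 2 is nearest to it with a lower number, and compound 3 is furthest, with a 6.8-fold lower number from compound 1 to compound 3 (0.84 log units; beyond the scatter). Compound 4 `Cc1ccc(-c2nc3sccn3c2/C=N/OCc2ccc(Cl)c(Cl)c2)cc1` differs from compound 1 by 4-methylphenyl in place of ethyl on an aromatic carbon. Within the data shown here, the one step that bears on it is the one from compound 1 to compound 3, where a larger aromatic group entered at the same carbon and the number fell beyond the scatter. An aromatic ring of one ring entering the same place is therefore expected to lower the number in this assay, though perhaps by less than the two-ring group did. Compound 4 is estimated at 600 nM, between 250 nM and 1500 nM, which means an expected step of a 4.3-fold lower number from compound 1 to compound 4 (0.64 log units; beyond the scatter).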

Compound 4, half-maximal effective concentration: 490 nM
Beside the measured number, compound 4's estimate is 1.2-fold (0.09 log units) above it, and the stated range covers the measured number.
By their numbers in this assay, from the lowest: compounds 3, 2 and 4 (each within the scatter of the next); then compound 1.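

In this assay a single aromatic ring in place of ethyl on this aromatic carbon gives a 5.3-fold lower number from compound 1 to compound 4 (0.72 log units; beyond the scatter) and so the drop does not depend on the two rings of naphthalen-2-yl. With a 1.3-fold higher number from compound 3 to compound 4 (0.11 log units; within the scatter) the two aromatic groups cannot be told apart at this position. Nothing measured explains this effect of the aromatic ring.

The compounds shown leave open whether unsubstituted phenyl would read like 4-methylphenyl. They also leave open how a cyclohexyl group, or a phenyl ring carrying an amine or a carboxylic acid, would read at this carbon.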